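This account rests on a few compounds, and the source may have more. Where it says the series, first, only, none or still open, it means among the compounds named here.

Compound 2 `CCCCCCCCCCCCCCOC(=O)NC(=O)Oc1c(C(C)C)cccc1C(C)C` holds the lower of the two numbers measured in an assay on microsomes from intestine for inhibition of acyl-CoA:cholesterol acyltransferase (Oryctolagus cuniculus); a higher number here means a weaker inhibitor, a lower number a stronger inhibitor: compound 2 gives 10 nM, while compound 1 `CCCCCCCCCCOC(=O)NC(=O)Oc1c(C(C)C)cccc1C(C)C` gives 74 nM. For the measured compounds named here, the single change between them, a longer chain, produced the step of a 7.4-fold lower number from compound 1 to compound 2 (0.87 log units; beyond the scatter). Compound 3 `CCCCCCCCCCCCCCCCOC(=O)NC(=O)Oc1c(C(C)C)cccc1C(C)C` carries a further lengthening of the same kind: ethyl in place of hydrogen on a saturated chain carbon, ten or more bonds along the chain from an oxygen next to a carbonyl group. Going by the values given here, only one measured step bears on this, a 7.4-fold lower number from compound 1 to compound 2 (0.87 log units; beyond the scatter), and it came from a larger addition at the same place with a modest gain. A smaller addition of the same sort is therefore expected to lower the number in this assay again, but by less, and possibly not beyond the scatter. The estimated step is a 1.7-fold lower number from compound 2 to compound 3 (0.22 log units; within the scatter). For compound 3 the expected value in this assay is 6 nM, with a range from 2 nM to 20 nM.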

Compound 3, half-maximal inhibitory concentration: 50 nM
Compound 3: the middle estimate sits 8.3-fold (0.92 log units) below what was measured, and the stated range ends below it.
By their numbers in this assay, from the lowest: compound 2; then compounds 3 and 1 (each within the scatter of the next).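

Lengthening this chain does not keep lowering the number in this assay: the ethyl addition at this place gives a 5.0-fold higher number from compound 2 to compound 3 (0.70 log units; beyond the scatter), which reverses the direction of the earlier step, a 7.4-fold lower number from compound 1 to compound 2 (0.87 log units; beyond the scatter). Taken across the whole change, the hexyl addition gives a 1.5-fold lower number from compound 1 to compound 3 (0.17 log units; within the scatter), so the shortest and longest chains of the three cannot be told apart, and among these three compounds the response to chain length rises and falls, with compound 2 alone at the lowest number. No measurement at hand bears on the reason for this turn.

Going by these compounds, how sharply the number changes with each added carbon, and whether a longer chain would raise it further, stay open. So does the outcome of a chain ending in a carboxylic acid or an amine at this place.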